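This account rests on a few compounds, and the source may have more. Where it says the series, first, only, none or still open, it means among the compounds named here.

Notes on the series. Compound 1 `Cc1cccc(-c2ccnc(C(=O)Nc3ccc(Oc4ccnc5[nH]ccc45)cc3)c2)c1` gives in a functional assay on MCF7 cells (Homo sapiens) for cytotoxicity, read by MTT assay, with a stated time of 72 h (a lower number here means a stronger inhibitor, a higher number a weaker inhibitor), 7470 nM. Compound 3 `Cc1cccc(-c2ccnc(C(=O)Nc3ccc(Oc4ccnc5[nH]ccc45)c(F)c3)c2)c1` gives in this assay 9120 nM; the step of a 1.2-fold higher number from compound 1 to compound 3 (0.09 log units; within the scatter) adds a fluoro to the aniline side of the shared core. Compound 2 `O=C(Nc1ccc(Oc2ccnc3[nH]ccc23)c(F)c1)c1ccc(-c2ccc(F)cc2)cn1` reaches only a limit of the assay in this assay, > 10000 nM. Among the numbers shown, compound 3 stands highest of two, with compound 1 nearest to it and within the scatter; the third value shown is a limit of > 10000 nM in this assay, at which 1 of the 3 values shown sits, and not a number.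

Compound 4 `O=C(Nc1ccc(Oc2ccnc3[nH]ccc23)c(F)c1)c1cc(-c2ccc(F)cc2)ccn1` differs from compound 3 by 4-fluorophenyl in place of 3-methylphenyl on an aromatic carbon. Going by the values given here, no measured step covers this exchange of one aryl group for another; the only measured step, a 1.2-fold higher number from compound 1 to compound 3 (0.09 log units; within the scatter), concerns a fluoro at the other end of the core and lay within the scatter. Among the compounds with values here, compound 2 carries the same 4-fluorophenyl and gives only a limit, but no single measured step links compound 2 to compound 4, so nothing is drawn from it. The expected step of a 1.1-fold higher number from compound 3 to compound 4 (0.04 log units; within the scatter) in this assay is therefore small, with no direction claimed beyond the scatter. Compound 4 is expected to give 10000 nM, in the range 4500 nM to 25000 nM.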

Compound 4, half-maximal inhibitory concentration: 9520 nM
Estimate against measurement, compound 4: 1.1-fold (0.02 log units) above; measured number inside the range.
By their numbers in this assay, from the lowest: compounds 1, 3 and 4 (each within the scatter of the next). At a limit, above all of these: compound 2.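

Exchanging 3-methylphenyl for 4-fluorophenyl on this aromatic carbon, opposite the ring nitrogen, leaves the number in this assay within the scatter (a 1.0-fold higher number from compound 3 to compound 4 (0.02 log units; within the scatter)). This is the only measured step at this position, and it shows that one aryl group can stand in for the other here without a change that can be told from the scatter; the fluoro step at the other end of the core had shown the same only for that place. No measured property shown bears on this step.

As far as these compounds go, whether an amine or a carboxylic acid in place of the aryl group on this carbon would give a step beyond the scatter stays open. From the compounds shown here alone, compound 2 stays a limit and not a number, so its distance from the other compounds also stays open.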